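The compounds below may be only part of what the source reports. "The series", "measured", "known", "first", "only" and "open" are said of these compounds alone.

Measured in a functional assay on MCF7 cells (Homo sapiens) for cytotoxicity, read by MTT assay, with a stated time of 72 h; a higher number here means a weaker inhibitor of growth, a lower number a stronger inhibitor of growth:

- compound 1 `N#C[Se]c1ccc(NC(=O)Oc2ccc(F)cc2)cc1`, compound 1 gives 33300 nM
- compound 2 `C=CCOC(=O)Nc1ccc([Se]C#N)cc1`, compound 2 gives 43100 nM
- compound 3 `O=C(Nc1ccc([Se][Se]c2ccc(NC(=O)OCc3ccc([N+](=O)[O-])cc3)cc2)cc1)OCc1ccc([N+](=O)[O-])cc1`, compound 3 gives 52800 nM

Compound 2 stands second highest of the three numbers, with compound 3 nearest and compound 1 furthest; both gaps lie within the scatter of this assay, so the three values cannot be told apart. Compound 4 `CCCCCCOC(=O)Nc1ccc([Se]C#N)cc1` is not yet measured. It differs from compound 2 at one place: pentyl in place of vinyl on a saturated chain carbon bound to an oxygen next to a carbonyl group. Among the compounds with values here, no pair of measured compounds differs by a change of this kind, so no measured step guides the expectation. The expected step from compound 2 to compound 4 is a 1.1-fold lower number from compound 2 to compound 4 (0.03 log units; within the scatter), that is, none beyond the scatter. Compound 4 is therefore estimated at 40000 nM, with a range from 15000 nM to 110000 nM.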

Compound 4, concentration for total growth inhibition: 30500 nM
Estimate against measurement, compound 4: 1.3-fold (0.12 log units) above; low and high end bracket the measured number.
By their numbers in this assay, from the lowest: compounds 4, 1, 2 and 3 (each within the scatter of the next).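

In this assay, within the data shown here, the only step at this place reads a 1.4-fold lower number from compound 2 to compound 4 (0.15 log units; within the scatter) and lies within the scatter. Swapping vinyl for pentyl on the saturated chain carbon bound to an oxygen next to a carbonyl group, which removes the double bond and adds carbon, therefore gives no change that can be resolved here. No measured evidence bears on this result.

On these data alone, whether an amine or a carboxylic acid at this place would move the number beyond the scatter remains open. The same holds for a longer chain.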